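Bromopyridine amides on a phenylpyrazole core: working notes

The source may report more compounds than this note shows. Statements on the series, on what has been measured and on what is new or still open speak of the compounds shown alone.

Measured in a functional assay on A-375 cells (Homo sapiens) for antiproliferative activity, read by MTT assay, with a stated time of 48 h; on this read-out higher numbers stand for weaker inhibition and lower numbers for stronger inhibition:
- compound 1, `O=C(Nc1cc(-c2ccccc2)[nH]n1)c1cncc(Br)c1`, gives 8120 nM
- compound 2, `O=C(Nc1cc(-c2ccccc2)[nH]n1)c1ccc(Br)nc1`, gives 8870 nM
- compound 3, `O=C(Nc1cc(-c2ccc(Br)cc2)[nH]n1)c1cncc(Br)c1`, gives 9420 nM

All three numbers sit close together. The step of a 1.1-fold higher number from compound 1 to compound 2 (0.04 log units; within the scatter) changes the acyl group, (6-bromopyridin-3-yl in place of 5-bromopyridin-3-yl on a carbonyl carbon), and the two values are not separated beyond the usual scatter. The step of a 1.2-fold higher number from compound 1 to compound 3 (0.06 log units; within the scatter) alters the core instead, (bromo in place of hydrogen on an aromatic carbon), and again the two numbers are not distinguishable. Compound 3 has the highest of the three numbers, but the gaps to compound 1 and to compound 2 are both within the scatter, so no order among the three is claimed.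

Compound 4, `O=C(Nc1cc(-c2ccc(Br)cc2)[nH]n1)c1ccc(Br)nc1`, has not yet been measured in this assay. Relative to compound 3 it carries 6-bromopyridin-3-yl in place of 5-bromopyridin-3-yl on a carbonyl carbon. This is the same change as from compound 1 to compound 2; the place is the same in both cases, a carbonyl carbon whose other neighbour is an amide-type nitrogen, only the core differs, as told by bromo in place of hydrogen on an aromatic carbon. Because a 1.1-fold higher number from compound 1 to compound 2 (0.04 log units; within the scatter) was within the scatter, the step of a 1.1-fold higher number from compound 3 to compound 4 (0.04 log units; within the scatter) is expected to be of the same small size, essentially flat. On that basis compound 4 is estimated at 10300 nM in this assay, with a range of 5500 nM to 19500 nM expected to cover the usual variation; only compounds 1 to 3 support this, and the combined change has not been observed directly.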

Compound 4, half-maximal inhibitory concentration: 9910 nM
Compound 4: middle estimate off by 1.0-fold (0.02 log units), on the high side; measured number inside the range.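

In this assay, 6-bromopyridin-3-yl in place of 5-bromopyridin-3-yl on a carbonyl carbon gives a 1.1-fold higher number from compound 3 to compound 4 (0.02 log units; within the scatter), and this change reads the same on both cores: the same change on two cores in this assay, a 1.1-fold higher number (0.04 log units; within the scatter) from compound 1 to compound 2 and a 1.1-fold higher number (0.02 log units; within the scatter) from compound 3 to compound 4, 1.0-fold (0.02 log units) apart, within the scatter of two such steps. Bromo in place of hydrogen on an aromatic carbon gives a 1.1-fold higher number from compound 2 to compound 4 (0.05 log units; within the scatter), and it too reads the same on both cores: the same change on two cores in this assay, a 1.2-fold higher number (0.06 log units; within the scatter) from compound 1 to compound 3 and a 1.1-fold higher number (0.05 log units; within the scatter) from compound 2 to compound 4, 1.0-fold (0.02 log units) apart, within the scatter of two such steps. Each change thus stays within the scatter on both cores, but this is only the carrying over of flat steps; it does not show that either change has any real effect on the read-out, or that a step of clear size would carry from one core to another in the same way.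

The compounds shown leave open whether any change in this series can move the number beyond the scatter, since the variation here is limited to where a bromo sits on the pyridine ring and whether a second bromo is present on the core. An amine, a carboxylic acid or a methoxy group in place of the bromo on the pyridine ring, or an unsubstituted pyridin-3-yl group on the carbonyl carbon, would test this and would also show whether the bromo matters at all.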